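Swapping the aryl group on a shared core

The source may report more compounds than this note shows. Statements on the series, on what has been measured and on what is new or still open speak of the compounds shown alone.

Three compounds share one core and differ only in the aryl group on a saturated ring carbon. Compound 1 `O=C(O)CC/C=C\CC1COC(c2ccccc2Cl)OC1c1cccnc1` gives 48 nM in an assay for inhibition of Thromboxane-A synthase (Homo sapiens), using microsomes; on this read-out lower numbers stand for stronger inhibition and higher numbers for weaker inhibition. Compound 2 `O=C(O)CC/C=C\CC1COC(c2ccc([N+](=O)[O-])cc2)OC1c1cccnc1` gives 39 nM in this assay, and compound 3 `O=C(O)CC/C=C\CC1COC(c2ccc(Cl)cc2Cl)OC1c1cccnc1` gives 42 nM in this assay. Compound 3 stands second highest of the three numbers, yet every step among them lies within the scatter: a 1.2-fold lower number from compound 1 to compound 2 (0.09 log units; within the scatter), a 1.1-fold lower number from compound 1 to compound 3 (0.06 log units; within the scatter) and a 1.1-fold higher number from compound 2 to compound 3 (0.03 log units; within the scatter). Compound 4 `O=C(O)CC/C=C\CC1COC(c2ccc(C(F)(F)F)cc2)OC1c1cccnc1` has not yet been measured in this assay. It differs from compound 3 by one change: 4-(trifluoromethyl)phenyl in place of 2,4-dichlorophenyl on a saturated ring carbon. The three measured steps bear on this change. Each of them also exchanged one aryl group for another at the same ring carbon, and each turned out small. On that basis the step of no change at the digits printed from compound 3 to compound 4 (within the scatter) is expected to stay within the scatter, in neither direction beyond it. Compound 4 is therefore estimated at 42 nM in this assay, with a range from 20 nM to 90 nM.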

Compound 4, half-maximal inhibitory concentration: 44 nM
Beside the measured number, compound 4's estimate is 1.0-fold (0.02 log units) below it; the range from low to high includes it.
By their numbers in this assay, from the lowest: compounds 2, 3, 4 and 1 (each within the scatter of the next).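

The fourth aryl group behaves like the first three at this ring carbon between two ring oxygen atoms. In this assay the exchange of 2,4-dichlorophenyl for 4-(trifluoromethyl)phenyl gives a 1.0-fold higher number from compound 3 to compound 4 (0.02 log units; within the scatter) and the exchange of nitro for trifluoromethyl on the aromatic carbon gives a 1.1-fold higher number from compound 2 to compound 4 (0.05 log units; within the scatter) while the exchange of 2-chlorophenyl for 4-(trifluoromethyl)phenyl gives a 1.1-fold lower number from compound 1 to compound 4 (0.04 log units; within the scatter) so the trifluoromethyl group, new to this series, shifts nothing beyond the scatter against any of the three earlier compounds. Nothing available explains this sameness among the four compounds.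

All four groups are phenyl rings carrying chloro, nitro or trifluoromethyl. As far as these compounds go, whether a phenyl ring bearing an amine or a carboxylic acid, or a longer chain in place of the ring, would read the same stays open.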